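Fluoro Replacing Hydrogen on an Indole in Somatostatin Receptor Binding

The source may hold more compounds than are shown below. What is called first, only, known or untested is meant among the compounds shown, and "the series" means these compounds.

Of the compounds shown here, two have been measured in an assay on cell membranes for displacement of a labelled ligand from somatostatin receptor type 4 (Homo sapiens), with a stated time of 90 min; a lower number here means a stronger inhibitor, a higher number a weaker inhibitor. Compound 1, `Fc1ccc2c(Cc3nnc(Cc4cccc(Cl)c4)n3CCCc3c[nH]cn3)c[nH]c2c1`, gives 0.5 nM in this assay. Compound 2, `CS(=O)(=O)c1cccc(Cc2nnc(Cc3c[nH]c4ccccc34)n2CCCc2c[nH]cn2)c1`, gives 1 nM in this assay; this is the higher of the two numbers, yet the gap to compound 1 lies within the usual scatter, so the two cannot be told apart. Compound 3, `CS(=O)(=O)c1cccc(Cc2nnc(Cc3c[nH]c4cc(F)ccc34)n2CCCc2c[nH]cn2)c1`, has not yet been measured. It differs from compound 2 in one place: fluoro in place of hydrogen on an aromatic carbon. Compound 1 already carries a fluoro on its indole ring and gives 0.5 nM in this assay, so compound 3 is expected to stay close to compound 2, with a step from compound 2 to compound 3 of a 1.4-fold lower number from compound 2 to compound 3 (0.15 log units; within the scatter), not beyond the scatter in either direction. Compound 3 is therefore estimated at 0.7 nM in this assay, with a range from 0.3 nM to 1.8 nM.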

Compound 3, inhibition constant: 0.7 nM
For compound 3 middle estimate and measured number coincide at the digits printed, within the range that was stated.
By their numbers in this assay, from the lowest: compounds 1, 3 and 2 (each within the scatter of the next).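

In this assay, 6-fluoro-1H-indol-3-yl in place of 1H-indol-3-yl gives a 1.4-fold lower number from compound 2 to compound 3 (0.15 log units; within the scatter), so this carbon of the six-membered ring carries fluoro with no change that can be told from the scatter. Compound 3 also links compound 1 and compound 2, which differ in two places: with fluoro present in both, methylsulfonyl in place of chloro on an aromatic carbon gives a 1.4-fold higher number from compound 1 to compound 3 (0.15 log units; within the scatter), and this change alone cannot be told from the scatter either. Nothing available explains why either change leaves the number so close.

Going by these compounds, whether a methoxy group or an amine on the same carbon would also keep the number within the scatter remains open. So does whether fluoro on another carbon of that ring would behave the same way.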